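A few compounds are considered here, and "the series" means these few. Any claim that something is new, unique, unknown or untested is made for them only; others in the source may bear on it.

Compound 2 `O=C(NS(=O)(=O)C1CC1)c1ccc(Nc2nc(NC3(c4ccc(Cl)cc4)CC3)nc(OCC(F)(F)F)n2)cc1` carries a cyclopropyl on its sulfonyl sulfur, and in an ADME assay on microsomes from liver (Homo sapiens) for metabolic stability, with a stated time of 10 min (on this read-out lower numbers stand for a less stable compound and higher numbers for a more stable compound), compound 2 gives 100%, the highest of the two numbers in hand. Among the compounds with values here, the only other compound measured, compound 1 `CC(C)C(=O)NCCS(=O)(=O)NC(=O)c1ccc(Nc2nc(NC3(c4ccc(Cl)cc4)CC3)nc(OCC(F)(F)F)n2)cc1`, bears a 2-((isopropylcarbonyl)amino)ethyl in that same place, and compound 1 gives 86%. Within the data shown here, the one step known, a number 14 percentage points higher from compound 1 to compound 2 (beyond the scatter), therefore shows that changing the group on the sulfonyl sulfur can move the result beyond the scatter, though only modestly.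

Compound 3 `Cc1ccccc1S(=O)(=O)NC(=O)c1ccc(Nc2nc(NC3(c4ccc(Cl)cc4)CC3)nc(OCC(F)(F)F)n2)cc1` differs from compound 2 in that same position: 2-methylphenyl in place of cyclopropyl on a sulfonyl sulfur. Among the measured compounds shown here, no step in hand involves a 2-methylphenyl, so the only guidance is the size of the one step at that sulfur. Since compound 2 already sits at the top of the scale, a rise cannot be expected; a step of about the size seen from compound 1 to compound 2, downward, or none beyond the scatter, seems plausible, and the expected step is a number 10 percentage points lower from compound 2 to compound 3 (within the scatter). Compound 3 is accordingly estimated to give 90%, with a likely range from 72% to 100%.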

Compound 3, percent of the compound remaining: 100%
Compound 3: middle estimate off by 10 percentage points, on the low side; the range from low to high includes it.
By their numbers in this assay, from the lowest: compound 1; then compounds 2 and 3 (each within the scatter of the next).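

In this assay, the sulfonyl sulfur accepts a six-membered aromatic ring carrying a methyl as readily as a three-membered non-aromatic ring: replacing cyclopropyl, with 3 heavy atoms, by 2-methylphenyl, with 7 heavy atoms, gives no change at the digits printed from compound 2 to compound 3 (within the scatter), so the larger group costs nothing measurable here. The second comparison, a number 14 percentage points higher from compound 1 to compound 3 (beyond the scatter), sets compound 1 and its 2-((isopropylcarbonyl)amino)ethyl apart from two different groups rather than one, while compound 2 and compound 3 cannot be told apart. No other measurement is at hand to account for these numbers.

Compound 2 and compound 3 share the same value at the very top of this read-out, so any difference in stability between them at the stated time remains hidden. As far as these compounds go, it also remains open whether a plain phenyl, a methyl or a simple propyl chain on the sulfonyl sulfur would stay level with these two, and whether a chain ending in an amine or a carboxylic acid would fall nearer to compound 1.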